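Compound 3 to compound 4: ethynyl to cyano

The source may report more compounds than this note shows. Statements on the series, on what has been measured and on what is new or still open speak of the compounds shown alone.

Measured in a functional assay on MIA PaCa-2 cells (Homo sapiens) for antiproliferative activity; on this read-out lower numbers stand for an effect already at smaller amounts and higher numbers for an effect only at larger amounts of compound:
- compound 1 `Cc1cc2c(C(N)=O)cccc2n1-c1nc2c(c(NCc3ccccc3)n1)CCCC2`: 128 nM
- compound 2 `C#CCNC(=O)c1cccc2c1cc(C)n2-c1nc2c(c(NCc3ccccc3)n1)CCCC2`: 470 nM
- compound 3 `C#CCCNC(=O)c1cccc2c1cc(C)n2-c1nc2c(c(NCc3ccccc3)n1)CCCC2`: 1410 nM

Compound 3 has the highest number of the three, at 1410 nM. Next in the series is compound 4 `Cc1cc2c(C(=O)NCCC#N)cccc2n1-c1nc2c(c(NCc3ccccc3)n1)CCCC2`, still unmeasured. The change is cyano in place of ethynyl on a saturated chain carbon, two bonds along the chain from an amide-type nitrogen.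

Among the compounds with values here, no measured step makes this exchange directly. The nearest evidence comes from changes at the same amide-type nitrogen: a 3.7-fold higher number from compound 1 to compound 2 (0.56 log units; beyond the scatter), an 11-fold higher number from compound 1 to compound 3 (1.04 log units; beyond the scatter) and a 3.0-fold higher number from compound 2 to compound 3 (0.48 log units; beyond the scatter). These steps are modest, large and modest. All three go upward, and none of the three compounds runs against that trend. They show that the chain matters in this assay, but they say nothing about cyano itself. No step beyond the scatter is therefore expected, with a slight lean towards a lower number. The expected step is a 1.4-fold lower number from compound 3 to compound 4 (0.15 log units; within the scatter). For compound 4 the estimate is 1000 nM, with an estimated range from 350 nM to 2800 nM.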

Compound 4, half-maximal effective concentration: 517 nM
Estimate against measurement, compound 4: 1.9-fold (0.29 log units) above, within the range that was stated.
By their numbers in this assay, from the lowest: compound 1; then compounds 2 and 4 (each within the scatter of the next); then compound 3.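

Within the data shown here, at this position in this assay, the group itself matters and not only the chain: cyano in place of ethynyl, on a saturated chain carbon two bonds along the chain from an amide-type nitrogen, gives a lower number (a 2.7-fold lower number from compound 3 to compound 4 (0.44 log units; beyond the scatter)), a change of group that the earlier steps did not cover. The 2-cyanoethyl group also brings compound 4 level with the shorter propargyl amide (a 1.1-fold higher number from compound 2 to compound 4 (0.04 log units; within the scatter)). Even so, 2-cyanoethyl in place of hydrogen on the amide-type nitrogen still costs activity (a 4.0-fold higher number from compound 1 to compound 4 (0.61 log units; beyond the scatter)), and compound 1 keeps the lowest number of the four.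

Nothing measured here accounts for the effect of this exchange. Still open, from the compounds shown here alone, is whether an amine, a carboxylic acid or a longer nitrile chain on the same nitrogen would come closer to compound 1.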